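This account rests on a few compounds, and the source may have more. Where it says the series, first, only, none or still open, it means among the compounds named here.

Three compounds built on a shared core have numbers in a functional assay on A549 cells (Homo sapiens) for inhibition, read by MTT assay, with a stated time of 72 h; a lower number here means a stronger inhibitor, a higher number a weaker inhibitor. Compound 1 (`COc1cc(N(C)CCN(C)C)c(NC(=O)C=C(C)C)cc1Nc1nc2c(c(-c3cn(C)c4ccccc34)n1)CS(=O)(=O)CC2`) gives 787 nM, compound 2 (`CC/C=C\C(=O)Nc1cc(Nc2nc3c(c(-c4cn(C)c5ccccc45)n2)CS(=O)(=O)CC3)c(OC)cc1N(C)CCN(C)C`) gives 1350 nM, and compound 3 (`COc1cc(N(C)CCN(C)C)c(NC(=O)C=C(C)C)cc1Nc1nc2c(c(-c3cn(C)c4ccc(F)cc34)n1)CS(=O)(=O)CC2`) gives 2140 nM. Putting fluoro in place of hydrogen on an aromatic carbon comes with a 2.7-fold higher number from compound 1 to compound 3 (0.43 log units; beyond the scatter), so the value of compound 3 stands clearly apart from that of compound 1. The values of compound 2 and compound 3, however, lie within the usual scatter of each other.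

Compound 4 (`CC/C=C\C(=O)Nc1cc(Nc2nc3c(c(-c4cn(C)c5ccc(F)cc45)n2)CS(=O)(=O)CC3)c(OC)cc1N(C)CCN(C)C`) has not been measured. It differs from compound 3 in one place: but-1-en-1-yl in place of 2-methylprop-1-en-1-yl on a carbonyl carbon. The two have the same atoms, joined differently, with but-1-en-1-yl in place of 2-methylprop-1-en-1-yl on a carbonyl carbon.

The same exchange has been measured once, in the pair without the fluoro, and there it gave a 1.7-fold higher number from compound 1 to compound 2 (0.23 log units; within the scatter). That single step is small and points toward a higher number, so only a slight rise, if any, seems reasonable here. One pair is thin evidence, and the exchange may behave differently alongside the fluoro. In this assay, the expected change is a 1.4-fold higher number from compound 3 to compound 4 (0.15 log units; within the scatter), which would not stand clear of the scatter. Compound 4 is estimated at 3000 nM, with an expected range of 1500 nM to 6000 nM.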

Compound 4, half-maximal inhibitory concentration: 5830 nM
Beside the measured number, compound 4's estimate is 1.9-fold (0.29 log units) below it; the measured number falls inside the stated range.
By their numbers in this assay, from the lowest: compounds 1, 2 and 3 (each within the scatter of the next, the first and the last beyond it); then compound 4.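

With the fluoro present, the exchange of 2-methylprop-1-en-1-yl for but-1-en-1-yl on a carbonyl carbon gives a step that stands clear of the scatter in this assay, a 2.7-fold higher number from compound 3 to compound 4 (0.44 log units; beyond the scatter), which the pair without the fluoro did not show. That does not prove that the fluoro alters the effect of the exchange, since the two steps for this change still agree: the same change on two cores in this assay, a 1.7-fold higher number (0.23 log units; within the scatter) from compound 1 to compound 2 and a 2.7-fold higher number (0.44 log units; beyond the scatter) from compound 3 to compound 4, 1.6-fold (0.20 log units) apart, within the scatter of two such steps The fluoro in place of hydrogen on an aromatic carbon can now also be read on a second core, where it gives a 4.3-fold higher number from compound 2 to compound 4 (0.64 log units; beyond the scatter), so this change comes with a higher number beyond the scatter on both cores, and the two steps agree: the same change on two cores in this assay, a 2.7-fold higher number (0.43 log units; beyond the scatter) from compound 1 to compound 3 and a 4.3-fold higher number (0.64 log units; beyond the scatter) from compound 2 to compound 4, 1.6-fold (0.20 log units) apart, within the scatter of two such steps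

As far as these compounds go, with only four compounds and one assay, it remains open whether the two changes simply add up or influence each other. From the compounds shown here alone, it is also open how a chloro or a methoxy would behave on that aromatic carbon, and how a longer chain or a chain carrying an amine would behave on the carbonyl carbon.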